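Swapping a Bromine for Fluorine on a Benzyl Group

The source may hold more compounds than are shown below. What is called first, only, known or untested is meant among the compounds shown, and "the series" means these compounds.

Of the compounds shown here, three built on a shared core have been tested in an ADME assay on MT4 cells (Homo sapiens) for cytotoxicity, read by MTT assay, with a stated time of 5 days; a lower number here means that less compound is tolerated, a higher number that more compound is tolerated. Compound 1, with structure `Cc1ccc(CN2C(=O)N(Cc3ccccc3)S(=O)(=O)n3cccc32)cc1`, gives 241000 nM in this assay. Compound 2, with structure `O=C1N(Cc2ccccc2Br)c2cccn2S(=O)(=O)N1Cc1cccc(F)c1`, reaches only the upper limit of this assay, reported as > 269000 nM. Compound 3, with structure `O=C1N(Cc2ccccc2Cl)c2cccn2S(=O)(=O)N1Cc1cccc(Br)c1`, likewise reaches only a limit in this assay, > 260000 nM, so no exact number is known for it; this is the limit described in the limit of > 260000 nM in this assay, at which 1 of the 3 values shown sits, and compound 2 sits at the neighbouring limit in the limit of > 269000 nM in this assay, at which 1 of the 3 values shown sits. Compound 1 stands close to both, and none of the three can be separated from the others.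

The next compound, compound 4, has structure `O=C1N(Cc2ccccc2Cl)c2cccn2S(=O)(=O)N1Cc1cccc(F)c1`. It differs from compound 3 in one place: fluoro in place of bromo on an aromatic carbon. Among the measured compounds shown here, no pair of measured compounds in this set shows the size of a change of this kind, so the expectation rests on how little the three measured values differ from one another. Compound 4 is expected to behave like compound 3, with a step that the limit leaves unreadable from compound 3 to compound 4, essentially no change beyond the usual scatter. For compound 4 the estimate in this assay is 265000 nM, within a range of 130000 nM to 530000 nM, and it is quite likely that the assay will again return only a limit.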

Compound 4, half-maximal cytotoxic concentration: 231000 nM
The estimate for compound 4 lay 1.1-fold (0.06 log units) above the measured number; low and high end bracket the measured number.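

Among the compounds shown here, with compound 4, the change from 3-bromobenzyl to 3-fluorobenzyl can be read for the first time in this assay, and the data give an at least 1.1-fold lower number from compound 3 to compound 4 (0.05 log units; that floor lies within the scatter). The change from bromo to chloro on the other benzyl group, with fluoro in place of bromo also separating the pair, can be read as well, and the data give an at least 1.1-fold lower number from compound 2 to compound 4 (0.06 log units; that floor lies within the scatter). Both steps are only floors that lie within the scatter, so neither shows that swapping one halogen for another at these places alters how much compound the cells tolerate, and the true size of the first step stays unknown because compound 3 gives a limit, not a number: the limit of > 260000 nM in this assay, at which 1 of the 4 values shown sits.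

Going by these compounds, compound 2 also gives only a limit, which leaves the true size of the second step unknown as well: the limit of > 269000 nM in this assay, at which 1 of the 4 values shown sits. Still open is whether a group of a different kind at this same place on the benzyl ring, such as an amine or a carboxylic acid, would move the number clearly beyond the scatter in this assay.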